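Diethylamino analogue expected to remain tolerated on Vero cells

This account rests on a few compounds, and the source may have more. Where it says the series, first, only, none or still open, it means among the compounds named here.

Compound 3 `CC(=O)Nc1ccc(-c2nc3cc(C(F)(F)F)ccc3n2C)cc1` carries an acetamido group on the shared core. In an ADME assay on Vero cells (Chlorocebus sabaeus) for cytotoxicity (a lower number here means that less compound is tolerated, a higher number that more compound is tolerated), compound 3 gives > 100000 nM, which is a limit of the assay and not a number. Compound 1 `CN1CCN(CC(=O)Nc2ccc(-c3nc4cc(C(F)(F)F)ccc4n3C)cc2)CC1` in this assay gives > 100000 nM, again only a limit. Compound 2 `Cn1c(-c2ccc(NC(=O)CN3CCCC3)cc2)nc2cc(C(F)(F)F)ccc21` gives > 100000 nM in this assay, also a limit. The steps among these three are therefore unreadable: a step that the two limits leave unreadable from compound 1 to compound 2, a step that the two limits leave unreadable from compound 1 to compound 3 and a step that the two limits leave unreadable from compound 2 to compound 3, each resting on (the limit of > 100000 nM in this assay, at which 3 of the 3 values shown sit).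

Compound 4 `CCN(CC)CC(=O)Nc1ccc(-c2nc3cc(C(F)(F)F)ccc3n2C)cc1` differs from compound 3 by diethylamino in place of hydrogen on a saturated chain carbon bound to a carbonyl carbon. The change resembles those that give compound 1 its 4-methylpiperazin-1-yl and compound 2 its pyrrolidin-1-yl on a saturated chain carbon bound to a carbonyl carbon, and both of those compounds sit at the limit, so no step beyond the scatter is expected. The expected step is a step that the limit leaves unreadable from compound 3 to compound 4. Compound 4 is therefore estimated at 150000 nM, within 80000 nM to 400000 nM, most likely reported again as a limit.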

Compound 4, half-maximal cytotoxic concentration: 90000 nM
Estimate against measurement, compound 4: 1.7-fold (0.22 log units) above; the measured number falls inside the stated range.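

In this assay, for the compounds shown here, compound 4 gives 90000 nM, the first value at this saturated chain carbon bound to a carbonyl carbon that is a number and not a limit of the assay. Set against the other compounds, it can be read only as an at least 1.1-fold lower number from compound 3 to compound 4 (0.04 log units; that floor lies within the scatter), an at least 1.1-fold lower number from compound 2 to compound 4 (0.04 log units; that floor lies within the scatter) and an at least 1.1-fold lower number from compound 1 to compound 4 (0.04 log units; that floor lies within the scatter), so diethylamino is not shown to differ from hydrogen, pyrrolidin-1-yl or 4-methylpiperazin-1-yl. Each of these steps gives only a floor, and none fixes a size: the limit of > 100000 nM in this assay, at which 3 of the 4 values shown sit.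

On these data alone, the steps among compound 1, compound 2 and compound 3 still cannot be read, and the true size of each step to compound 4 remains open. Also open, as far as these compounds go, is whether a morpholin-4-yl group, a primary amine or a carboxylic acid on this carbon would give a number in this assay.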